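Ring-nitrogen acylation in a bis(trifluoromethyl)anilide series

The source may report more compounds than this note shows. Statements on the series, on what has been measured and on what is new or still open speak of the compounds shown alone.

Measured so far:
compound 1 `CCCC(=O)N1c2ccccc2CCC1C(=O)Nc1cc(C(F)(F)F)cc(C(F)(F)F)c1`: 15000 nM
compound 2 `O=C(Nc1cc(C(F)(F)F)cc(C(F)(F)F)c1)C1CCc2ccccc2N1`: 8410 nM

Both compounds were run in a functional assay on NCI-H23 cells (Homo sapiens) for cytotoxicity, read by sulforhodamine B assay, with a stated time of 72 h; on this read-out higher numbers stand for weaker inhibition of growth and lower numbers for stronger inhibition of growth. Within the data shown here, compound 1 gives 15000 nM and compound 2 gives 8410 nM; the two sit within the scatter of each other, as the only measured step shows: a 1.8-fold lower number from compound 1 to compound 2 (0.25 log units; within the scatter), hydrogen in place of propylcarbonyl on the ring nitrogen. Compound 2 therefore holds no separate standing among the numbers in hand beyond being the free ring-nitrogen analogue.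

Compound 3 `O=C(Nc1cc(C(F)(F)F)cc(C(F)(F)F)c1)C1CCc2ccccc2N1C(=O)c1cccc(Cl)c1` returns an acyl group to that nitrogen: (3-chlorophenyl)carbonyl in place of hydrogen on a nitrogen on an aromatic ring in a ring. The step from compound 1 to compound 2 is the only measured one that bears on this change, and it is the reverse operation with a different acyl group; its size was within the scatter. On that basis no step beyond the scatter is expected in this assay, with at most a small drift toward a higher number in line with the direction seen for compound 1. Compound 3 is expected to give 12000 nM, in a range from 4000 nM to 40000 nM, which means an estimated step of a 1.4-fold higher number from compound 2 to compound 3 (0.15 log units; within the scatter).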

Compound 3, concentration for 50% growth inhibition: 420 nM
Estimate against measurement, compound 3: 29-fold (1.46 log units) above; measured number outside the range, below it.
By their numbers in this assay, from the lowest: compound 3; then compounds 2 and 1 (each within the scatter of the next).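

In this assay the ring nitrogen turns out to be sensitive to which acyl group it carries, a point the earlier pair could not show, since a 1.8-fold lower number from compound 1 to compound 2 (0.25 log units; within the scatter) left propylcarbonyl and hydrogen unseparated. Placing (3-chlorophenyl)carbonyl on that nitrogen in place of hydrogen gives a 20-fold lower number from compound 2 to compound 3 (1.30 log units; beyond the scatter) and so opens a clear separation from the free ring-nitrogen analogue, but acylation alone does not account for it, as compound 1 goes against any such general rule. With the carbonyl kept and only its substituent changed, 3-chlorophenyl in place of propyl gives a 36-fold lower number from compound 1 to compound 3 (1.55 log units; beyond the scatter), which ties the large step to the group on the carbonyl carbon, while nothing at hand gives a measured reason for it.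

Going by these compounds, whether the step belongs to the aromatic ring or to its chlorine stays open, and a plain phenylcarbonyl group on the same nitrogen would separate the two. Also open, on these data alone, is whether a cyclohexylcarbonyl group would track with propylcarbonyl or with (3-chlorophenyl)carbonyl, and whether the same order holds in other cell lines.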